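A few compounds are considered here, and "the series" means these few. Any claim that something is new, unique, unknown or untested is made for them only; others in the source may bear on it.

Working notes on the series. For the measured compounds named here, in a functional assay on Jurkat cells (Homo sapiens) for inhibition, read by MTT assay, with a stated time of 24 h (on this read-out higher numbers stand for weaker inhibition and lower numbers for stronger inhibition), compound 2 `O=[N+]([O-])c1ccc(Cl)cc1CNc1cc(C(F)(F)F)cc2[nH]ncc12` stands lowest of the two numbers so far at 1100 nM and so shows the stronger inhibition. Compound 1 `O=[N+]([O-])c1cc(Cl)ccc1CNc1cc(C(F)(F)F)cc2[nH]ncc12` gives the higher number of 8040 nM with a gap beyond the scatter. Compound 3 `O=[N+]([O-])c1ccccc1CNc1cc(C(F)(F)F)cc2[nH]ncc12` departs from compound 2 with hydrogen in place of chloro on an aromatic carbon para to a nitro group. Going by the values given here, neither measured compound lacks the chloro, and no measured pair isolates this change, so any expectation is loose. In this assay a moderate move towards a higher number, meaning weaker inhibition, is expected. The expected step is a 2.5-fold higher number from compound 2 to compound 3 (0.41 log units; beyond the scatter) on this estimate. For compound 3 the estimated value is 2800 nM with 900 nM to 8000 nM as its expected range.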

Compound 3, half-maximal inhibitory concentration: > 20000 nM
Compound 3: only a limit was reported (the forecaster's own chance of this, stated with the estimate: 3%); middle value at least 7.1-fold (0.85 log units) away from the limit.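

In this assay compound 3 gives > 20000 nM, which is a limit of the assay and not a number. Hydrogen in place of chloro on this aromatic carbon, para to a nitro group, gives an at least 18-fold higher number from compound 2 to compound 3 (1.25 log units; beyond the scatter), and the same exchange at the other chloro place gives an at least 2.4-fold higher number from compound 1 to compound 3 (0.39 log units; beyond the scatter), so the series now shows that a chloro in either place gives a lower number than no chloro at all, whereas the earlier pair showed only that its place matters. Neither step has a known upper size because the value of compound 3 is capped: the limit of > 20000 nM in this assay, at which 1 of the 3 values shown sits.

The compounds shown leave open whether a fluoro, a methoxy or an amine on this aromatic carbon would match the chloro of compound 2. They also leave open whether the gain from chloro persists when a nitrile replaces the nitro group.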